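From cyclobutyloxy to methoxy on the shared core

A few compounds are considered here, and "the series" means these few. Any claim that something is new, unique, unknown or untested is made for them only; others in the source may bear on it.

Among the compounds with values here, compound 2 `NC(=O)c1ccc(-c2cccnc2)cc1OC1CCC1` gives 1900 nM in an assay on cells for inhibition of MAP kinase-interacting serine/threonine-protein kinase 1 (Homo sapiens), read by mobility shift assay, with stated times of 10 min and 60 min, in the presence of a further agent that is not named here (a higher number here means a weaker inhibitor, a lower number a stronger inhibitor), the lower of the two numbers so far, while compound 1 `CCNc1cc(-c2cccnc2)ccc1C(N)=O` gives 58000 nM. Within the data shown here, the only measured step, a 31-fold lower number from compound 1 to compound 2 (1.48 log units; beyond the scatter), changed both the attaching atom and the group, so it bears only loosely on compound 3 `COc1cc(-c2cccnc2)ccc1C(N)=O`, which differs from compound 2 by methyl in place of cyclobutyl on an oxygen on an aromatic ring. Among the measured compounds shown here, with no direct precedent, a moderate rise in the number is the expectation, and compound 3 is estimated to show a 3.2-fold higher number from compound 2 to compound 3 (0.50 log units; beyond the scatter). Compound 3 is therefore expected to give 6000 nM, with a range from 2000 nM to 20000 nM.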

Compound 3, half-maximal inhibitory concentration: 2800 nM
For compound 3 the middle estimate is 2.1-fold (0.33 log units) above the measured one; measured number inside the range.
By their numbers in this assay, from the lowest: compounds 2 and 3 (each within the scatter of the next); then compound 1.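

In this assay, replacing cyclobutyl with methyl on this oxygen gives only a small step (a 1.5-fold higher number from compound 2 to compound 3 (0.17 log units; within the scatter)), so the four-membered ring is not needed to hold the number within the scatter of compound 2. Methoxy in place of ethylamino on the aromatic carbon also gives a large step (a 21-fold lower number from compound 1 to compound 3 (1.32 log units; beyond the scatter)), so the gain seen with cyclobutyloxy recurs with methyl on the oxygen. Nothing measured here accounts for either step. The compounds shown leave open how ethoxy or a hydroxyl group would read at this place, and whether methylamino would behave like ethylamino.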